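The source may report more compounds than this note shows. Statements on the series, on what has been measured and on what is new or still open speak of the compounds shown alone.

Three compounds share one core and differ only in a single group on the fused ring. Compound 1 `CCCCN(c1nc2ccccc2o1)[C@H](C)c1ccc(-c2ccccc2-c2nnn[nH]2)cc1` carries hydrogen there, and in an ADME assay on the whole organism (Macaca fascicularis) for pharmacokinetics, read by LC-MS, using cassette dosing, at a dose of 1 mg/kg by the oral route (a higher number here means more compound in the circulation at the dose given, a lower number less compound in the circulation), compound 1 gives 44.3 ng.h/mL. Compound 2 `CCCCN(c1nc2c(C(=O)NC)cccc2o1)[C@H](C)c1ccc(-c2ccccc2-c2nnn[nH]2)cc1` carries methylcarbamoyl, and in this assay compound 2 gives 25.7 ng.h/mL. Compound 3 `CCCCN(c1nc2c(C(=O)NS(C)(=O)=O)cccc2o1)[C@H](C)c1ccc(-c2ccccc2-c2nnn[nH]2)cc1` carries (methylsulfonyl)carbamoyl, and in this assay compound 3 gives 22.2 ng.h/mL. Compound 3 sits at the low end of these three numbers, but it is not separated from the others: there is a 2.0-fold lower number from compound 1 to compound 3 (0.30 log units; within the scatter) and a 1.2-fold lower number from compound 2 to compound 3 (0.06 log units; within the scatter), both within the scatter.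

Compound 4 `CCCCN(c1nc2c(-c3ccccn3)cccc2o1)[C@H](C)c1ccc(-c2ccccc2-c2nnn[nH]2)cc1` introduces a new group at the same spot: pyridin-2-yl in place of (methylsulfonyl)carbamoyl on an aromatic carbon. Within the data shown here, every step measured at this position so far has stayed within the scatter, whatever group was placed there, and no measured step involves a ring group. With only this to go on, compound 4 is expected to show a 1.4-fold higher number from compound 3 to compound 4 (0.13 log units; within the scatter), a change of no real size. The estimate for compound 4 is therefore 30 ng.h/mL, with a range from 12 ng.h/mL to 75 ng.h/mL.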

Compound 4, area under the concentration-time curve: 248 ng.h/mL
For compound 4 the middle estimate is 8.3-fold (0.92 log units) below the measured one; measured number outside the range, above it.
By their numbers in this assay, from the lowest: compounds 3, 2 and 1 (each within the scatter of the next); then compound 4.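

The position is not indifferent in this assay: pyridin-2-yl in place of the earlier groups gives an 11-fold higher number from compound 3 to compound 4 (1.05 log units; beyond the scatter), a 9.6-fold higher number from compound 2 to compound 4 (0.98 log units; beyond the scatter) and a 5.6-fold higher number from compound 1 to compound 4 (0.75 log units; beyond the scatter), all beyond the scatter. Hydrogen, methylcarbamoyl and (methylsulfonyl)carbamoyl could not be told apart here, whereas this ring stands clear of all three, including the compound with only hydrogen at this carbon, which makes it a real gain over the bare core and not merely a return from a lower number. No measurement shown here explains this rise.

A phenyl ring, with carbon in place of the pyridine nitrogen, would show whether the ring alone is enough or the ring nitrogen also matters. The single oral exposure figure also leaves open whether more compound is entering the circulation or less is leaving it.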